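Cytotoxicity notes on the series, towards compound 4

The compounds below may be only part of what the source reports. "The series", "measured", "known", "first", "only" and "open" are said of these compounds alone.

Measured compounds, cytotoxicity on liver-derived cells:
compound 1, `CC(Sc1nnc(-c2ccncc2)s1)C(=O)NCc1ccccc1`: > 50000 nM
compound 2, `O=C(CCSc1nnc(-c2ccncc2)s1)NCc1ccccc1`: 14000 nM
compound 3, `S=c1[nH]nc(-c2ccncc2)s1`: 19700 nM

In an ADME assay on HepG2 cells (Homo sapiens) for cytotoxicity, with a stated time of 3 days (on this read-out lower numbers stand for higher toxicity in this test and higher numbers for lower toxicity in this test), compound 2 gives 14000 nM. The entry for compound 1 is a limit of the assay, not a number (the limit of > 50000 nM in this assay, at which 1 of the 3 values shown sits). Compound 3 gives 19700 nM in this assay, which sits within the scatter of the value of compound 2; no order between the two can be read. Compound 2 thus holds the lowest of the two plain numbers shown, with compound 3 its nearest neighbour and compound 1 known only as a limit.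

Compound 4, `O=C(CCSc1nnc(-c2ccncc2)s1)Nc1ccccc1Cl`, is the next member to be tested in this assay. Against compound 2 the change is 2-chlorophenyl in place of benzyl on an amide-type nitrogen. Among the measured compounds shown here, no pair of measured compounds differs in a single place, so the series offers no measured step of this kind to lean on; the thioether, the amide and the shared core of compound 2 are kept unchanged.

The expected step is a 1.4-fold lower number from compound 2 to compound 4 (0.15 log units; within the scatter), small and not beyond the scatter, leaning if anything towards a somewhat lower number. Compound 4 is expected to give 10000 nM in this assay, within a range from 3500 nM to 30000 nM.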

Compound 4, half-maximal cytotoxic concentration: > 50000 nM
Compound 4 was reported as a limit (the forecaster's own chance of this, stated with the estimate: 15%); at least 5.0-fold (0.69 log units) between middle value and limit.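

Among the compounds shown here, on the amide-type nitrogen, in this assay, 2-chlorophenyl in place of benzyl gives an at least 3.5-fold higher number from compound 2 to compound 4 (0.55 log units; beyond the scatter), the only step that can be read at a single place and one that lies beyond the scatter. With the thioether, the amide and the shared core kept unchanged, this exchange alone moves the read-out, which compound 1, compound 2 and compound 3 could not show, as no two of them differ in one place. The entry for compound 4 is a limit of the assay and not a number, so the step has a lower bound only, and the entry coincides with the assay's ceiling: the limit of > 50000 nM in this assay, at which 2 of the 4 values shown sit.

The change swaps the ring substituent and removes the carbon link to the nitrogen in one move, so the compounds shown leave open which part carries the step; plain phenyl or 2-chlorobenzyl on the same nitrogen would divide the two. Also open, as far as these compounds go, is whether the read-out at this place holds with a carboxylic acid or an amine on that aromatic ring in place of the chlorine.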